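The compounds below may be only part of what the source reports. "The series", "measured", "known", "first", "only" and "open" are said of these compounds alone.

Among the measured compounds shown here, compound 3 `CCc1ccc(C(=O)Nc2cccc(NC(=O)COc3ccc4c(=O)ccoc4c3)c2)cc1` stands second highest of the three numbers so far in an assay on isolated protein for inhibition of Rho-associated protein kinase 2 (Homo sapiens), read by scintillation counting, radiometric assay and 33P incorporation, with a stated time of 40 min, in the presence of a further agent that is not named here (a lower number here means a stronger inhibitor, a higher number a weaker inhibitor), where compound 3 gives 24 nM. The nearest number is that of compound 2 `O=C(COc1ccc2c(=O)ccoc2c1)Nc1cccc(NC(=O)c2ccccc2)c1`, which in this assay gives 16 nM. The step between them is a 1.5-fold higher number from compound 2 to compound 3 (0.18 log units; within the scatter). The furthest is compound 1 `CCCC(=O)Nc1cccc(NC(=O)COc2ccc3c(=O)ccoc3c2)c1`, which in this assay gives 176 nM. That difference reads a 7.3-fold lower number from compound 1 to compound 3 (0.87 log units; beyond the scatter), and the related change to the unsubstituted ring is an 11-fold lower number from compound 1 to compound 2 (1.04 log units; beyond the scatter).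

Compound 4 `CC(C)(C)c1ccc(C(=O)Nc2cccc(NC(=O)COc3ccc4c(=O)ccoc4c3)c2)cc1` differs from compound 3 in one place: tert-butyl in place of ethyl on an aromatic carbon. For the measured compounds named here, the only measured step at that same aromatic carbon is the ethyl-for-hydrogen change, a 1.5-fold higher number from compound 2 to compound 3 (0.18 log units; within the scatter), which lies within the scatter. The two larger steps, an 11-fold lower number from compound 1 to compound 2 (1.04 log units; beyond the scatter) and a 7.3-fold lower number from compound 1 to compound 3 (0.87 log units; beyond the scatter), concern the group on the carbonyl carbon, not the position changed here, so they do not speak directly to this step. On that basis no step beyond the scatter is expected in this assay from compound 3 to compound 4, in either direction; the expected step is a 1.1-fold higher number from compound 3 to compound 4 (0.03 log units; within the scatter). Compound 4 is therefore estimated at 26 nM in this assay, with a range from 10 nM to 65 nM.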

Compound 4, half-maximal inhibitory concentration: 34 nM
Compound 4: middle estimate off by 1.3-fold (0.12 log units), on the low side; low and high end bracket the measured number.
By their numbers in this assay, from the lowest: compounds 2, 3 and 4 (each within the scatter of the next, the first and the last beyond it); then compound 1.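

Going from ethyl to tert-butyl on this aromatic carbon in this assay gives no step beyond the scatter (a 1.4-fold higher number from compound 3 to compound 4 (0.15 log units; within the scatter)), yet the step from the unsubstituted ring now passes the scatter, though only modestly (a 2.1-fold higher number from compound 2 to compound 4 (0.33 log units; beyond the scatter)), whereas the ethyl step from compound 2 to compound 3 stayed within it. Read across compounds 2, 3 and 4, hydrogen, ethyl and tert-butyl therefore form a shallow drift in the numbers, visible only between the two ends of the set and not at either single step. The 4-(tert-butyl)phenyl group still keeps a clear advantage over propyl on the carbonyl carbon (a 5.2-fold lower number from compound 1 to compound 4 (0.71 log units; beyond the scatter)), so the larger group on the aromatic ring does not cancel the gain seen with the ring in place of the chain. No measurement at hand accounts for the size of these steps.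

As far as these compounds go, only hydrogen and alkyl groups appear at this aromatic carbon, so the effect of an amine, a carboxylic acid or a methoxy group there remains open. On the carbonyl carbon, propyl is the only chain, and a longer chain could show whether the ring itself matters or chain length alone.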